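A few compounds are considered here, and "the series" means these few. Any claim that something is new, unique, unknown or untested is made for them only; others in the source may bear on it.

Compound 1 `Nc1nc(-c2ccco2)nc2sc(CN3CCC(F)CC3)cc12` gives 740 nM in an assay on CHO-K1 cells for antagonist activity at adenosine receptor A1 (Homo sapiens), read by a beta-galactosidase reporter, with stated times of 15 min and 6 h; on this read-out lower numbers stand for stronger inhibition and higher numbers for weaker inhibition. Compound 2 `Nc1nc(-c2ccco2)nc2sc(CN3CCC(O)CC3)cc12` gives 4000 nM.

Among these two numbers compound 1 stands lowest. Going by the values given here, the only measured step, a 5.4-fold higher number from compound 1 to compound 2 (0.73 log units; beyond the scatter), concerns a saturated ring at a different part of the shared core. Compound 3 `N#Cc1ccccc1-c1nc(N)c2cc(CN3CCC(F)CC3)sc2n1` differs from compound 1 by 2-cyanophenyl in place of furan-2-yl on an aromatic carbon. Among the compounds with values here, no measured step touches this aromatic position, so the size of the step is uncertain and the wide range reflects that. Compound 3 is expected to give 1500 nM, within 200 nM to 10000 nM. The expected step is a 2.0-fold higher number from compound 1 to compound 3 (0.31 log units; beyond the scatter), toward a weaker value.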

Compound 3, inhibition constant: 5050 nM
Compound 3: middle estimate off by 3.4-fold (0.53 log units), on the low side, within the range that was stated.
By their numbers in this assay, from the lowest: compound 1; then compounds 2 and 3 (each within the scatter of the next).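

Going by these compounds alone, this is the first measured change at the aromatic carbon between two ring nitrogen atoms. In this assay, 2-cyanophenyl in place of furan-2-yl gives a 6.8-fold higher number from compound 1 to compound 3 (0.83 log units; beyond the scatter) on this read-out, so the group at this position does affect the result, and furan-2-yl goes with the lower number of the two. No evidence here explains the shift.

Going by these compounds, it remains open whether plain phenyl would give a number closer to compound 1 or to compound 3. That leaves unsettled whether the larger ring or its nitrile accounts for the step.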